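The source may hold more compounds than are shown below. What is called first, only, known or untested is meant among the compounds shown, and "the series" means these compounds.

Notes on the series. The shared core carries a 4-sulfamoylphenyl group on the ring nitrogen and a variable group on a saturated ring carbon. Compound 1 `N#CC1=C(N)N(c2ccc(S(N)(=O)=O)cc2)C2=C(CCCC2)C1c1ccccc1O` bears 2-hydroxyphenyl there; in a functional assay on Ehrlich cells (Mus musculus) for cytotoxicity, read by trypan blue exclusion, with a stated time of 2 h, tested at 10 ug/mL (a lower number here means a weaker effect, a higher number a stronger effect of the compound at the concentration tested), compound 1 gives 10%. Compound 2 `N#CC1=C(N)N(c2ccc(S(N)(=O)=O)cc2)C2=C(CCCC2)C1c1ccc(O)cc1` bears 4-hydroxyphenyl, and in this assay compound 2 gives 20%; the step is a number 10 percentage points higher from compound 1 to compound 2 (within the scatter). Compound 3 `N#CC1=C(N)N(c2ccc(S(N)(=O)=O)cc2)C2=C(CCCC2)C1/C=C/c1ccccc1` bears 2-phenylethenyl, and in this assay compound 3 gives 50%, the highest of the three numbers, with both a number 40 percentage points higher from compound 1 to compound 3 (beyond the scatter) and a number 30 percentage points higher from compound 2 to compound 3 (beyond the scatter) beyond the scatter.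

Compound 4 `COc1ccccc1C1C(C#N)=C(N)N(c2ccc(S(N)(=O)=O)cc2)C2=C1CCCC2` differs from compound 3 in one place: 2-methoxyphenyl in place of 2-phenylethenyl on a saturated ring carbon. The step that bears on this change is a number 40 percentage points higher from compound 1 to compound 3 (beyond the scatter). Compound 1 likewise carries a 2-substituted phenyl, 2-hydroxyphenyl, on the saturated ring carbon, and compound 4 carries 2-methoxyphenyl; the change from compound 3 to compound 4 largely runs that step backwards, with the hydroxy replaced by methoxy. Among the measured compounds shown here, no measured pair separates a hydroxy from a methoxy on this phenyl, so that part of the change is unsupported. A drop of roughly the size of the step from compound 1 to compound 3 is therefore expected in this assay.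

The number for compound 4 is expected at 15%, between 5% and 35%, which means an expected step of a number 35 percentage points lower from compound 3 to compound 4 (beyond the scatter).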

Compound 4, a percentage reported as activity, at one concentration (the size of the read-out at that concentration, not a potency): 30%
Estimate against measurement, compound 4: 15 percentage points below, within the range that was stated.
By their numbers in this assay, from the lowest: compounds 1, 2 and 4 (each within the scatter of the next, the first and the last beyond it); then compound 3.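

In this assay, methyl in place of hydrogen on the oxygen of the 2-hydroxyphenyl group gives the first measured separation of hydroxy from methoxy at this saturated ring carbon, and the change is not silent: a number 20 percentage points higher from compound 1 to compound 4 (beyond the scatter). Replacing 2-phenylethenyl with 2-methoxyphenyl still costs activity, with a number 20 percentage points lower from compound 3 to compound 4 (beyond the scatter), so compound 3 remains the highest of the four, although a substituted phenyl here need not sit as low as compound 1 does. Against the 4-hydroxyphenyl group of compound 2, the 2-methoxyphenyl group gives a number 10 percentage points higher from compound 2 to compound 4 (within the scatter), so these two cannot be ordered, and nothing available explains any of these steps.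

From the compounds shown here alone, it remains open whether methyl on the oxygen has a similar effect on the 4-hydroxyphenyl group, and whether 4-methoxyphenyl, an ethoxy group or an amine on the phenyl ring would follow compound 4. Also open, going by these compounds, is whether the double bond of 2-phenylethenyl matters, which the saturated 2-phenylethyl group would test directly.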